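Urea heteroaryl isomers in the FAAH series

The source may report more compounds than this note shows. Statements on the series, on what has been measured and on what is new or still open speak of the compounds shown alone.

Compound 1 `O=C(Nc1noc2ccccc12)N1CCN(Cc2cccc(Oc3ccc(Cl)cc3)c2)CC1`: 8.1 nM in an assay on isolated protein for inhibition of Fatty-acid amide hydrolase 1 (Rattus norvegicus), with a stated time of 60 min; a lower number here means a stronger inhibitor, a higher number a weaker inhibitor
Compound 2 `O=C(Nc1cn2ccccc2n1)N1CCN(Cc2cccc(Oc3ccc(Cl)cc3)c2)CC1`: > 10000 nM in this assay

Compound 2 sits at the limit of this assay, (the limit of > 10000 nM in this assay, at which 1 of the 2 values shown sits), so only a bound is known for it. Compound 3 `O=C(Nc1cccn2ccnc12)N1CCN(Cc2cccc(Oc3ccc(Cl)cc3)c2)CC1` differs from compound 2 by a group of 9 heavy atoms (7 carbon, 2 nitrogen; one five-membered aromatic ring with 2 hetero atoms, one six-membered aromatic ring with 1 hetero atom) in place of a group of 9 heavy atoms (7 carbon, 2 nitrogen; one five-membered aromatic ring with 2 hetero atoms, one six-membered aromatic ring with 1 hetero atom), on an amide-type nitrogen. For the measured compounds named here, the one measured step, an at least 1200-fold higher number from compound 1 to compound 2 (3.09 log units; beyond the scatter), shows that this position tolerates little variation in the heteroaryl group. Going by the values given here, no measured pair maps the present rearrangement, so the direction of the step is uncertain. Compound 3 is expected to remain weak, near the bound, with an at least 1.2-fold lower number from compound 2 to compound 3 (0.09 log units; that floor lies within the scatter) as the estimated step. The estimate for compound 3 is 8000 nM, within 800 nM to 30000 nM.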

Compound 3, half-maximal inhibitory concentration: 3500 nM
Compound 3: the middle estimate sits 2.3-fold (0.36 log units) above what was measured, within the range that was stated.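

Rearranging the same atoms within the heteroaryl group on the amide-type nitrogen gives an at least 2.8-fold lower number from compound 2 to compound 3 (0.45 log units; beyond the scatter), so this position responds to arrangement alone, with atom counts unchanged. The value of compound 2 is a limit of the assay, not a number: the limit of > 10000 nM in this assay, at which 1 of the 3 values shown sits. A large gap remains, a 430-fold higher number from compound 1 to compound 3 (2.64 log units; beyond the scatter), and neither group with 2 nitrogen atoms closes it.

As far as these compounds go, whether the oxygen in the group of compound 1 or its overall ring arrangement matters more stays open. So does the response to a simple phenyl or pyridine on this nitrogen.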